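A few compounds are considered here, and "the series" means these few. Any claim that something is new, unique, unknown or untested is made for them only; others in the source may bear on it.

In a functional assay on a cell-free system (plasma) for inhibition of thromboxane A2 receptor (Homo sapiens), read by turbidimetry (a higher number here means a weaker inhibitor, a lower number a stronger inhibitor), three compounds built on one shared core have been measured. Compound 1 `O=C(O)COCCCC[C@H]1[C@H](F)CC[C@@H]1NS(=O)(=O)c1ccc(F)cc1F` gives 1800 nM. Compound 2 `O=C(O)CC/C=C\C[C@H]1[C@H](F)CC[C@@H]1NS(=O)(=O)c1ccc(F)cc1` gives 750 nM, the second highest of the three numbers. Compound 3 `O=C(O)CC/C=C\C[C@H]1[C@H](F)CC[C@@H]1NS(=O)(=O)c1ccc(Cl)cc1` gives 210 nM, the lowest of them. Within the data shown here, the only pair that differs in a single place is compound 2 and compound 3: a 3.6-fold lower number from compound 2 to compound 3 (0.55 log units; beyond the scatter). That step concerns the halogen on the aromatic ring, not the chain that carries the acid. Compound 4 `O=C(O)CCCCCC[C@H]1[C@H](F)CC[C@@H]1NS(=O)(=O)c1ccc(F)cc1` differs from compound 2 only in that chain: 5-carboxypentyl in place of 4-carboxybut-1-en-1-yl on a saturated chain carbon bound to a saturated ring carbon. Compound 1 also carries a different chain, but it differs from compound 2 in the aromatic ring as well, so its higher number cannot be credited to the chain alone. Among the measured compounds shown here, no measured step therefore bears directly on the change to compound 4, and the data give no ground to expect a step beyond the scatter in this assay. The expected outcome for compound 4 is 900 nM, between 300 nM and 2700 nM. That estimate means an expected step of a 1.2-fold higher number from compound 2 to compound 4 (0.08 log units; within the scatter).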

Compound 4, half-maximal inhibitory concentration: 2400 nM
Beside the measured number, compound 4's estimate is 2.7-fold (0.43 log units) below it; the measured number falls inside the stated range.
By their numbers in this assay, from the lowest: compound 3; then compound 2; then compounds 1 and 4 (each within the scatter of the next).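

Replacing 4-carboxybut-1-en-1-yl with 5-carboxypentyl gives a 3.2-fold higher number from compound 2 to compound 4 (0.51 log units; beyond the scatter) in this assay, so the chain that carries the acid matters at this position, on a saturated chain carbon bound to a saturated ring carbon. Among these compounds, until now, the only single-place step concerned the halogen on the aromatic ring, a 3.6-fold lower number from compound 2 to compound 3 (0.55 log units; beyond the scatter), and said nothing about the chain. The new chain has 8 heavy atoms in place of 7 and 1 double bond outside aromatic rings in place of 2, and no measurement here explains why the number rises.

Because chain length and the double bond change together, the step cannot be assigned to either one alone, and a 4-carboxybutyl chain would have the length of the original chain without its double bond. On these data alone, whether chloro in place of fluoro gives a similar step on the 5-carboxypentyl chain also remains open.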